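The source may report more compounds than this note shows. Statements on the series, on what has been measured and on what is new or still open speak of the compounds shown alone.

For the measured compounds named here, the compounds measured so far: compound 1 `COc1ccc2c(c1)c(-c1cc(C(F)(F)F)c(C#N)c(-c3cn(S(=O)(=O)c4ccc(C)cc4)c4ccc(OC)cc34)n1)cn2S(=O)(=O)c1ccc(C)cc1` gives 24.4% in a functional assay on A549 cells (Homo sapiens) for inhibition, tested at 1 uM; on this read-out lower numbers stand for a weaker effect and higher numbers for a stronger effect at the one concentration tested; compound 2 `COc1ccc2c(-c3cc(C(F)(F)F)c(C#N)c(-c4cn(S(=O)(=O)c5ccc(C)cc5)c5cc(OC)ccc45)n3)cn(S(=O)(=O)c3ccc(C)cc3)c2c1` gives 26.7%; compound 3 `COc1ccc2c(c1)c(-c1cc(C(F)(F)F)ccn1)cn2S(=O)(=O)c1ccc(C)cc1` gives 23.2%.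

Among these three numbers compound 3 has the lowest, yet its gap to compound 1 and its gap to compound 2 both lie within the usual scatter, so the three cannot be told apart on this read-out. Compound 4 `Cc1ccc(S(=O)(=O)n2cc(-c3cc(C(F)(F)F)ccn3)c3ccccc32)cc1` has not yet been measured. It differs from compound 3 in one place: hydrogen in place of methoxy on an aromatic carbon. Going by the values given here, no pair of measured compounds separated by a single change is available to weigh this step against. The three measured numbers sit close together, and the step is therefore expected to be small, none beyond the scatter. The expected step is a number 1.2 percentage points lower from compound 3 to compound 4 (within the scatter). Compound 4 is expected to give 22%, with a range from 12% to 32%.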

Compound 4, a percentage reported as inhibition, at one concentration (the size of the read-out at that concentration, not a potency): 29.2%
Compound 4: the middle estimate sits 7.2 percentage points below what was measured; the range from low to high includes it.
By their numbers in this assay, from the lowest: compounds 3, 1, 2 and 4 (each within the scatter of the next).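

In this assay, for the compounds shown here, putting hydrogen in place of methoxy on this aromatic carbon gives a number 6 percentage points higher from compound 3 to compound 4 (within the scatter) and is the only single-place step available in this set. At the one concentration tested, the read-out therefore does not separate compound 4 from compound 3, and the methoxy at this position is not shown to matter. Nothing on hand explains this step. Going by these compounds, whether an amine, a hydroxyl or a longer alkoxy chain at this place would move the number beyond the scatter stays open. So does the behaviour of this change at other concentrations.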